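The source may report more compounds than this note shows. Statements on the series, on what has been measured and on what is new or still open speak of the compounds shown alone.

Measured compounds:
compound 1 `COc1cc(-c2cc(/C=C/C(=O)c3ccc(N)cc3)[nH]n2)cc(OC)c1OC` — 6790 nM
compound 2 `COc1ccc(-c2cc(/C=C/C(=O)c3ccc(OC)c(OC)c3)[nH]n2)cc1` — 6330 nM

In a functional assay on NCI-H23 cells (Homo sapiens) for inhibition, read by sulforhodamine B assay, with a stated time of 48 h (a lower number here means a stronger inhibitor of growth, a higher number a weaker inhibitor of growth), compound 1 gives 6790 nM, the higher of the two numbers. Compound 2, in this assay, gives 6330 nM, and this lies within the scatter of compound 1, so the two cannot be told apart. Compound 3 `COc1cc(-c2cc(/C=C/C(=O)c3ccc(Cl)c(Cl)c3)[nH]n2)cc(OC)c1OC` has not yet been measured. It differs from compound 1 in one place: 3,4-dichlorophenyl in place of 4-aminophenyl on a carbonyl carbon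

Within the data shown here, with no measured pair that shows this change, the step is expected to be small, not clearly beyond the scatter, and of uncertain direction. Compound 3 is estimated at 5000 nM, within 1500 nM to 16000 nM, which would mean an expected step of a 1.4-fold lower number from compound 1 to compound 3 (0.13 log units; within the scatter).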

Compound 3, concentration for total growth inhibition: > 100000 nM
Compound 3: only a limit was reported (the forecaster's own chance of this, stated with the estimate: 5%); at least 20-fold (1.30 log units) between middle value and limit.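

This position is not indifferent to its group: on the carbonyl carbon, 3,4-dichlorophenyl in place of 4-aminophenyl gives an at least 14-fold higher number from compound 1 to compound 3 (1.16 log units; beyond the scatter) in this assay. Compound 3 is reported only as a limit of the assay, > 100000 nM, so the full size of the step cannot be read: the limit of > 100000 nM in this assay, at which 1 of the 3 values shown sits.

This one step cannot separate the loss of the amino group from the entry of the two chlorines. As far as these compounds go, it remains open how a 4-chlorophenyl, a 4-hydroxyphenyl or a 4-(dimethylamino)phenyl group on that carbonyl carbon would compare with compound 1.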